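The source may hold more compounds than are shown below. What is called first, only, known or untested is meant among the compounds shown, and "the series" means these compounds.

Compound 3 (`COc1ccc2c(c1)c(C1CC(c3ccccc3)=NN1C(=O)c1cccnc1)cn2C`) stands at > 10000 nM in a functional assay on A549 cells (Homo sapiens) for inhibition, read by MTT assay, with a stated time of 48 h (a higher number here means a weaker inhibitor of growth, a lower number a stronger inhibitor of growth), which is a limit of the assay and not a number. Compound 2 (`Cn1cc(C2CC(c3ccccc3)=NN2C(=O)c2cccnc2)c2cc(Br)ccc21`), with bromo in place of the methoxy on the shared core, gives 1600 nM. Going by the values given here, the one measured step is an at least 6.2-fold higher number from compound 2 to compound 3 (0.79 log units; beyond the scatter). Compound 4 (`COc1ccc2c(c1)c(C1CC(c3ccccc3)=NN1C(=O)c1ccc(OC)nc1)cn2C`) differs from compound 3 as follows: methoxy in place of hydrogen on an aromatic carbon. This is pyridin-3-yl to 6-methoxypyridin-3-yl, with methoxy in place of hydrogen on an aromatic carbon.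

The measured step involves a methoxy too, but at another place, so it bears only loosely on this change. Compound 1 (`COc1ccc(C(=O)N2N=C(c3ccccc3)CC2c2cn(C)c3ccccc23)cn1`) carries the same 6-methoxypyridin-3-yl group without a methoxy on the shared core and gives 3040 nM. That value suggests the group is compatible with a measurable number, so a modest move toward a lower number is expected, though a second limit reading remains possible. The expected change is an at least 1.2-fold lower number from compound 3 to compound 4 (0.09 log units; that floor lies within the scatter). The estimate for compound 4 is 8000 nM, with an expected range of 3000 nM to 20000 nM.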

Compound 4, concentration for 50% growth inhibition: 1110 nM
The estimate for compound 4 lay 7.2-fold (0.86 log units) above the measured number; the measured number lies below the stated range.
By their numbers in this assay, from the lowest: compounds 4, 2 and 1 (each within the scatter of the next, the first and the last beyond it). At a limit, above all of these: compound 3.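

In this assay, methoxy in place of hydrogen next to the ring nitrogen gives an at least 9.0-fold lower number from compound 3 to compound 4 (0.95 log units; beyond the scatter), so this position can turn a reading at the limit into a measurable number on the methoxy-bearing core. Methoxy on the shared core also no longer goes with a higher number once 6-methoxypyridin-3-yl is present, giving a 2.7-fold lower number from compound 1 to compound 4 (0.44 log units; beyond the scatter), so the two methoxy groups do not act independently across compounds 1 to 4, and compound 3 is the compound that goes against a simple benefit of core methoxy. The reading for compound 3 is a limit of the assay and not a number, which leaves the true step size open: the limit of > 10000 nM in this assay, at which 1 of the 4 values shown sits.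

On these data alone, it remains open whether an amine or an ethoxy group at the same place would match methoxy. As far as these compounds go, whether the same change would lower the number with bromo on the shared core also remains open.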